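Alkynyl variations on a shared core: benzofuranyl in place of fluorophenyl

The compounds below may be only part of what the source reports. "The series", "measured", "known", "first", "only" and "open" are said of these compounds alone.

Compound 1 `CNC(=O)[C@@]12C[C@@H]1[C@@H](n1cnc3c(NC)nc(C#Cc4ccccc4F)nc31)[C@H](O)[C@@H]2O` is the reference; in an assay on CHO cells for displacement of a labelled ligand from adenosine receptor A1 (Homo sapiens), read by scintillation counting, with a stated time of 60 min, tested at 10 uM (a higher number here means more inhibition at the concentration tested (going by the name of the read-out), a lower number less inhibition), compound 1 gives 20%, the highest of the three numbers, though its steps to both other compounds stay within the scatter. Compound 2 `CNC(=O)[C@@]12C[C@@H]1[C@@H](n1cnc3c(NC)nc(C#Cc4cccc(F)c4)nc31)[C@H](O)[C@@H]2O` gives 14% and compound 3 `CNC(=O)[C@@]12C[C@@H]1[C@@H](n1cnc3c(NC)nc(C#Cc4cccnc4)nc31)[C@H](O)[C@@H]2O` gives 16%. The steps of a number 6 percentage points lower from compound 1 to compound 2 (within the scatter) and a number 4 percentage points lower from compound 1 to compound 3 (within the scatter) show that swapping the ring on the triple-bonded carbon has moved nothing beyond the scatter so far. Compound 4 `CNC(=O)[C@@]12C[C@@H]1[C@@H](n1cnc3c(NC)nc(C#Cc4cc5ccccc5o4)nc31)[C@H](O)[C@@H]2O` carries the change (1-benzofuran-2-yl in place of 2-fluorophenyl on a triple-bonded carbon). Among the measured compounds shown here, no measured step covers this ring, so the expectation rests on the flat picture above. Compound 4 is therefore expected to give 18% (range 5% to 38%), a step of a number 2 percentage points lower from compound 1 to compound 4 (within the scatter) estimated as none beyond the scatter.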

Compound 4, a percentage reported as inhibition, at one concentration (the size of the read-out at that concentration, not a potency): 13%
Compound 4: middle estimate off by 5 percentage points, on the high side, and the stated range covers the measured number.
By their numbers in this assay, from the lowest: compounds 4, 2, 3 and 1 (each within the scatter of the next).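

In this assay the steps of a number 7 percentage points lower from compound 1 to compound 4 (within the scatter) and a number 3 percentage points lower from compound 3 to compound 4 (within the scatter) and a number 1 percentage points lower from compound 2 to compound 4 (within the scatter) show that 1-benzofuran-2-yl, with a five-membered aromatic ring added to the six-membered one, also moves nothing beyond the scatter. On this triple-bonded carbon, a group with two aromatic rings therefore reads the same as the single-ring groups, and all four compounds remain within the scatter of one another. No supporting measurement bears on this result.

Open, going by these compounds, is whether a basic amine or a carboxylic acid on the ring, or a longer alkyl chain in its place, would give a step beyond the scatter. Also open, on these data alone, is how the compounds compare at other concentrations, as each number comes from a single one.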